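The compounds below may be only part of what the source reports. "The series", "measured", "known", "first", "only" and "open" are said of these compounds alone.

Working notes on the series. The shared core is held constant while the ring on the thiocarbonyl carbon is varied. Compound 1 `O=c1c(Cl)c(CSC(=S)N2CCCCC2)oc2ccccc12` carries piperidin-1-yl there and gives 770 nM in a functional assay on MDA-MB-435S cells (Homo sapiens) for antiproliferative activity, read by MTT assay, with a stated time of 72 h; on this read-out higher numbers stand for weaker inhibition and lower numbers for stronger inhibition. Within the data shown here, compound 2 `O=c1c(Cl)c(CSC(=S)N2CCCC2)oc2ccccc12` carries pyrrolidin-1-yl and gives 1800 nM in this assay; among the two numbers so far, compound 2 holds the higher one, and the step of a 2.3-fold higher number from compound 1 to compound 2 (0.37 log units; beyond the scatter) is the only measured step.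

Compound 3 `O=c1c(Cl)c(CSC(=S)N2CCOCC2)oc2ccccc12` is the next member, and it has not yet been measured in this assay. It differs from compound 2 in one place: morpholin-4-yl in place of pyrrolidin-1-yl on a thiocarbonyl carbon. Among the measured compounds shown here, only the step from compound 1 to compound 2 bears on this change, and only in part, since it covers the move between a five- and a six-membered ring without the added ring oxygen; it was modest, at a 2.3-fold higher number from compound 1 to compound 2 (0.37 log units; beyond the scatter). For the measured compounds named here, the return to a six-membered ring in compound 3 makes a number somewhat lower than that of compound 2 plausible, but the oxygen in the ring has no precedent here, so the expected step of a 1.2-fold lower number from compound 2 to compound 3 (0.08 log units; within the scatter) is small and may well fall within the scatter. Compound 3 is therefore estimated at 1500 nM in this assay, with a range from 500 nM to 5000 nM.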

Compound 3, half-maximal inhibitory concentration: 4100 nM
Beside the measured number, compound 3's estimate is 2.7-fold (0.44 log units) below it; low and high end bracket the measured number.
By their numbers in this assay, from the lowest: compound 1; then compound 2; then compound 3.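

Morpholin-4-yl in place of pyrrolidin-1-yl on a thiocarbonyl carbon gives a 2.3-fold higher number from compound 2 to compound 3 (0.36 log units; beyond the scatter) in this assay, so a return to a six-membered ring does not by itself bring back the lower number held by compound 1. Among these compounds, the comparison at equal ring size is the more telling one: morpholin-4-yl in place of piperidin-1-yl gives a 5.3-fold higher number from compound 1 to compound 3 (0.73 log units; beyond the scatter), and the ring oxygen is the only atom change in that step. Ring size alone therefore does not order the three compounds, since compound 2, with the only five-membered ring, has a lower number than compound 3 and a higher number than compound 1, and the identity of the ring atoms also counts at this position.

No measurement at hand accounts for the higher number that accompanies the ring oxygen. Still open is how a piperazin-1-yl ring, with a second ring nitrogen, or an open-chain diethylamino group would compare at this thiocarbonyl carbon with the three rings shown.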